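The compounds below may be only part of what the source reports. "The series", "measured", "known", "first", "only" and "open" are said of these compounds alone.

In an assay for inhibition of Polyunsaturated fatty acid lipoxygenase ALOX15 (Oryctolagus cuniculus), read by spectrophotometry (on this read-out lower numbers stand for stronger inhibition and higher numbers for weaker inhibition), compound 2 `C=CCOC(=O)NS(=O)(=O)Nc1cc(-c2cc3cc(F)ccc3[nH]2)ccc1OC` gives 23300 nM. Going by the values given here, the only other compound measured, compound 1 `COc1ccc(-c2cc3cc(F)ccc3[nH]2)cc1NS(=O)(=O)NC(=O)OCC(C)C`, gives 20800 nM in this assay, so the two numbers sit together; the step of a 1.1-fold higher number from compound 1 to compound 2 (0.05 log units; within the scatter) shows how close they lie. Compound 3 `CCCCCCCCOC(=O)NS(=O)(=O)Nc1cc(-c2cc3cc(F)ccc3[nH]2)ccc1OC` is the unmeasured analogue, and its difference from compound 2 is heptyl in place of vinyl on a saturated chain carbon bound to an oxygen next to a carbonyl group. Among the compounds with values here, the one measured step that touches this same saturated chain carbon bound to an oxygen next to a carbonyl group is a 1.1-fold higher number from compound 1 to compound 2 (0.05 log units; within the scatter), which swapped one small chain for another without moving the number beyond the scatter. Within the data shown here, that is the only guide available, and it suggests the chain at this place has had little bearing on the number so far. Compound 3 is therefore expected to land near compound 2, with a step of a 1.1-fold lower number from compound 2 to compound 3 (0.02 log units; within the scatter), giving an estimate of 22000 nM and a range from 8000 nM to 60000 nM.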

Compound 3, half-maximal inhibitory concentration: 1080 nM
Beside the measured number, compound 3's estimate is 20-fold (1.31 log units) above it, outside the stated range (below it).
By their numbers in this assay, from the lowest: compound 3; then compounds 1 and 2 (each within the scatter of the next).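

The place turns out to be far from indifferent: in this assay, heptyl in place of vinyl on a saturated chain carbon bound to an oxygen next to a carbonyl group gives a 22-fold lower number from compound 2 to compound 3 (1.33 log units; beyond the scatter) and heptyl in place of isopropyl gives a 19-fold lower number from compound 1 to compound 3 (1.28 log units; beyond the scatter) on the same scale. The earlier swap between the two small groups stayed within the scatter, so only the heptyl chain shows that this place can move the number strongly. Nothing available explains this large drop.

Going by these compounds, whether the number keeps falling with a longer chain such as dodecyl remains open. So does what a chain carrying a carboxylic acid or an amine, or a phenyl ring, would do at this place.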